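Methyl for trifluoromethyl in a diacylhydrazine series

This account rests on a few compounds, and the source may have more. Where it says the series, first, only, none or still open, it means among the compounds named here.

Compounds measured so far: compound 1 `CC(C)(C)N(NC(=O)c1ccccc1)C(=O)c1ccccc1Cl`, 75.9 nM; compound 2 `CC(C)(C)N(NC(=O)c1ccccc1)C(=O)c1ccccc1Br`, 170 nM; compound 3 `CC(C)(C)N(NC(=O)c1ccccc1)C(=O)c1ccccc1C(F)(F)F`, 631 nM.

All three share one core and differ only in one group on an aromatic carbon. In an assay on cells for agonist activity at ecdysone receptor (Bombyx mori), read by a luciferase reporter, with a stated time of 24 h (on this read-out higher numbers stand for an effect only at larger amounts of compound and lower numbers for an effect already at smaller amounts), compound 3 gives the highest number of the three: the steps run a 2.2-fold higher number from compound 1 to compound 2 (0.35 log units; beyond the scatter), an 8.3-fold higher number from compound 1 to compound 3 (0.92 log units; beyond the scatter) and a 3.7-fold higher number from compound 2 to compound 3 (0.57 log units; beyond the scatter), so compound 3 stands furthest from compound 1 and nearest to compound 2.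

Compound 4 `Cc1ccccc1C(=O)N(NC(=O)c1ccccc1)C(C)(C)C` is not yet measured. It differs from compound 3 as follows: methyl in place of trifluoromethyl on an aromatic carbon. All three measured steps bear on this change, since each replaces one group on that same aromatic carbon; two of them are modest and one is larger, and each of them runs upward toward compound 3. The step from compound 3 to compound 4 is therefore expected to run downward, beyond the scatter, roughly of the size seen between compound 2 and compound 3, and compound 4 is expected to give about 140 nM in this assay, with a range from 45 nM to 450 nM, which corresponds to an expected step of a 4.5-fold lower number from compound 3 to compound 4 (0.65 log units; beyond the scatter).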

Compound 4, half-maximal effective concentration: 224 nM
Beside the measured number, compound 4's estimate is 1.6-fold (0.20 log units) below it; the range from low to high includes it.
By their numbers in this assay, from the lowest: compound 1; then compounds 2 and 4 (each within the scatter of the next); then compound 3.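

In this assay, replacing trifluoromethyl with methyl on this aromatic carbon, ortho to a large group, gives a 2.8-fold lower number from compound 3 to compound 4 (0.45 log units; beyond the scatter) and leaves trifluoromethyl with the highest number of the four groups. Methyl cannot be separated from bromo at this position, with a 1.3-fold higher number from compound 2 to compound 4 (0.12 log units; within the scatter) staying within the scatter, whereas chloro remains clearly apart from methyl, with a 3.0-fold higher number from compound 1 to compound 4 (0.47 log units; beyond the scatter) giving chloro the lowest number of the four. No measurement given here accounts for this ranking of the groups.

Going by these compounds, the four compounds cover only chloro, bromo, trifluoromethyl and methyl on this one carbon, so it remains open where a fluoro, a methoxy or a nitrile would fall in this order. On these data alone, it also remains open whether the same order would hold for these groups on another aromatic carbon.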